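The source may hold more compounds than are shown below. What is called first, only, known or untested is meant among the compounds shown, and "the series" means these compounds.

Measured compounds:
compound 1, `Cc1ccccc1-n1nncc1CN1C(=O)C2(C(C#N)=C(N)Oc3c2c2nc4ccccc4nc2c2ccccc32)c2ccccc21`
compound 2, `N#CC1=C(N)Oc2c(c3nc4ccccc4nc3c3ccccc23)C12C(=O)N(Cc1cnnn1-c1ccc(F)cc1)c1ccccc12`
compound 3, `N#CC1=C(N)Oc2c(c3nc4ccccc4nc3c3ccccc23)C12C(=O)N(Cc1cnnn1-c1cccc(Cl)c1)c1ccccc12`

In an ADME assay on L02 cells (Homo sapiens) for antiproliferative activity, read by MTT assay, with a stated time of 48 h (a higher number here means a weaker inhibitor, a lower number a stronger inhibitor), compound 1 gives > 50000 nM, a limit of the assay rather than a number. Compound 2 gives > 50000 nM in this assay, again a limit. Among the measured compounds shown here, compound 3 gives 35200 nM in this assay; it is the only number in the set. The values of compound 1 and compound 2 are limits of the assay (the limit of > 50000 nM in this assay, at which 2 of the 3 values shown sit). The step of an at least 1.4-fold lower number from compound 1 to compound 3 (0.15 log units; that floor lies within the scatter) and the step of an at least 1.4-fold lower number from compound 2 to compound 3 (0.15 log units; that floor lies within the scatter) both carry a floor that lies within the usual scatter, so they show little beyond the fact that compound 3 is read at all. The step that the two limits leave unreadable from compound 1 to compound 2 is unreadable between two limits.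

Compound 4, `N#CC1=C(N)Oc2c(c3nc4ccccc4nc3c3ccccc23)C12C(=O)N(Cc1cnnn1-c1ccc(Br)cc1)c1ccccc12`, is not yet measured. It differs from compound 3 in one place: 4-bromophenyl in place of 3-chlorophenyl on an aromatic nitrogen. Both measured steps that end at compound 3 swap one aryl group on the same aromatic nitrogen for another, and neither resolves a size. Among the three aryl groups seen, only the 3-chlorophenyl compound returns a number; no measured step leads from a 3-chlorophenyl group to a 4-bromophenyl group, so no direction can be drawn from the data. Compound 4 is therefore expected to sit near compound 3, within the scatter, with a fair chance that this assay again reports only a limit. The expected step of a 1.1-fold higher number from compound 3 to compound 4 (0.06 log units; within the scatter) is small. The estimate for compound 4 is 40000 nM, with a range from 18000 nM to 100000 nM.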

Compound 4, half-maximal inhibitory concentration: > 50000 nM
Compound 4: only a limit was reported; the forecaster's own chance of this, stated with the estimate: 45%; at least 1.2-fold (0.09 log units) between middle value and limit.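

In this assay, the change to 4-bromophenyl on an aromatic nitrogen gives an at least 1.4-fold higher number from compound 3 to compound 4 (0.15 log units; that floor lies within the scatter), so this pair shows no resolved size and no firm direction for the change. The steps to compound 4 from compound 1 and from compound 2 join two limits and cannot be read. With 4-bromophenyl now grouped with 2-methylphenyl and 4-fluorophenyl at the same limit, the 3-chlorophenyl of compound 3 remains the only aryl group at this position with a number, and the series has gained a further limit rather than a further number: the limit of > 50000 nM in this assay, at which 3 of the 4 values shown sit.

The pair also changes the halogen and its place on the phenyl ring together, so a 4-chlorophenyl or a 3-bromophenyl group would be needed to tell those two changes apart. Also open, as far as these compounds go, is whether anything other than a directly attached substituted phenyl at this nitrogen, such as a benzyl group, a short alkyl chain or an aminoalkyl chain, would give numbers clearly apart from the limit in this assay.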